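Phenyl in place of hexyl: what compound 3 may show

The source may report more compounds than this note shows. Statements on the series, on what has been measured and on what is new or still open speak of the compounds shown alone.

compound 1 `CN(C)CCNc1ccnc2cc(OCc3ccc(F)cc3)ccc12`: 580 nM
compound 2 `CCCCCCCCOc1ccc2c(Cl)ccnc2c1`: 3640 nM

Going by the values given here, only two compounds have numbers so far in a functional assay on RKO cells (Homo sapiens) for cytotoxicity, read by MTT assay, with a stated time of 48 h (a higher number here means a weaker inhibitor, a lower number a stronger inhibitor), and they differ from each other in more than one place. Compound 2 gives 3640 nM as the higher of the two numbers, which makes it the weaker inhibitor of the pair. Its gap to compound 1 at 580 nM lies beyond the scatter. That gap cannot be tied to any single structural change.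

Compound 3 `Clc1ccnc2cc(OCCc3ccccc3)ccc12` has not yet been measured. It departs from compound 2 at one place, with phenyl in place of hexyl on a saturated chain carbon, two bonds along the chain from an oxygen on an aromatic ring.

Among the compounds with values here, no measured pair shows what such a swap does, so no direction can be argued firmly. In this assay the expectation is therefore no change beyond the scatter. The expected move is a 1.2-fold higher number from compound 2 to compound 3 (0.09 log units; within the scatter) and it remains only an estimate. For compound 3 the estimated value is 4500 nM with an expected range of 1800 nM to 12000 nM.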

Compound 3, half-maximal inhibitory concentration: 2560 nM
Beside the measured number, compound 3's estimate is 1.8-fold (0.24 log units) above it; the measured number falls inside the stated range.
By their numbers in this assay, from the lowest: compound 1; then compounds 3 and 2 (each within the scatter of the next).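

In this assay, going by these compounds alone, putting phenyl in place of hexyl on a saturated chain carbon, two bonds along the chain from an oxygen on an aromatic ring, gives the first step that can be read at a single place (a 1.4-fold lower number from compound 2 to compound 3 (0.15 log units; within the scatter)). At this place, then, an open chain of six carbon atoms and a six-membered aromatic ring of carbon only, each with the same count of heavy atoms and no hydrogen-bond donors or acceptors, are not told apart by this read-out. No measurement shown here accounts for this result.

Compound 2 and compound 3 each differ in more than one place from compound 1 (580 nM), so no single structural change can yet be tied to the value of that compound. On these data alone, it also remains open whether an amine, a carboxylic acid or a longer chain at this same place would move the number beyond the scatter, or whether this position tolerates such groups as evenly as it does hexyl and phenyl.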